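The compounds below may be only part of what the source reports. "The series", "measured", "known", "first", "only" and "open" are said of these compounds alone.

Compounds measured so far:
Compound 1, `COc1ccc(F)cc1Nc1cc(NC(=O)Nc2c(Cl)cccc2Cl)ncn1`: 85.5%
Compound 2, `COc1cc(NC(=O)Nc2cc(Nc3cc(F)ccc3OC)ncn2)cc(OC)c1`: 59.5%

In a functional assay on PC-9 cells (Homo sapiens) for inhibition, read by MTT assay, with a stated time of 48 h, tested at 10 uM (a lower number here means less inhibition, a higher number more inhibition at the concentration tested (going by the name of the read-out)), compound 1 gives 85.5%, the highest of the two numbers; compound 2 sits a number 26 percentage points lower from compound 1 to compound 2 (beyond the scatter), a step beyond the scatter, and that step concerns the aryl group on the amide-type nitrogen. Compound 3, `O=C(Nc1cc(Nc2ccc(F)c(Cl)c2)ncn1)Nc1c(Cl)cccc1Cl`, is reached from compound 1 by a change at a different place: 3-chloro-4-fluorophenyl in place of 5-fluoro-2-methoxyphenyl on a nitrogen on an aromatic ring. Going by the values given here, the one measured step does not touch this nitrogen, so nothing recorded speaks directly to the change from compound 1 to compound 3. The step from compound 1 to compound 2 shows that swapping one aryl group for another can move this assay by a modest amount, so a change of similar or smaller size, in either direction, is the most that can be anticipated. Compound 3 is therefore expected to give 75%, within 50% to 95%, which means an estimated step of a number 10.5 percentage points lower from compound 1 to compound 3 (beyond the scatter) in this assay.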

Compound 3, a percentage reported as inhibition, at one concentration (the size of the read-out at that concentration, not a potency): 91.1%
For compound 3 the middle estimate is 16.1 percentage points below the measured one; measured number inside the range.
By their numbers in this assay, from the lowest: compound 2; then compounds 1 and 3 (each within the scatter of the next).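

At the nitrogen on an aromatic ring, 3-chloro-4-fluorophenyl in place of 5-fluoro-2-methoxyphenyl gives, in this assay, (a number 5.6 percentage points higher from compound 1 to compound 3 (within the scatter)), so the two groups are not told apart by this read-out. The earlier step, a number 26 percentage points lower from compound 1 to compound 2 (beyond the scatter), concerned only the amide-type nitrogen; this pair shows that, with 2,6-dichlorophenyl kept on that nitrogen, the methoxy group of compound 1 is not needed for a high number, since compound 3 lacks it and gives 91.1% in the same assay. Nothing available explains this result.

Both substituents of the aryl ring change together in this pair, so the contribution of each one stays unresolved. Also open, on these data alone, is whether a morpholine, a simple alkyl chain or an aryl ring carrying an amine at this nitrogen would keep the number as high.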